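This account rests on a few compounds, and the source may have more. Where it says the series, first, only, none or still open, it means among the compounds named here.

In a functional assay on Raji cells (Homo sapiens) for inhibition, read by MTT assay, with a stated time of 96 h (on this read-out higher numbers stand for weaker inhibition and lower numbers for stronger inhibition), compound 1 `CCC(C)Oc1cc(NC(=O)/C(C#N)=C(/C)O)c(F)cc1-c1cccc(OC(F)(F)F)c1` gives 130 nM and compound 2 `CCC(C)Oc1cc(NC(=O)/C(C#N)=C(/C)O)c(F)cc1-c1cccc2ccccc12` gives 215 nM within the scatter of compound 1. Compound 3 `COc1cccc(-c2cc(F)c(NC(=O)/C(C#N)=C(/C)O)cc2OC(C)C)c1` gives 981 nM as a clearly higher number than compound 2. Compound 4 `CCC(C)Oc1cc(NC(=O)/C(C#N)=C(/C)O)c(F)cc1-c1ccc2ccccc2c1` differs from compound 2 in one place (naphthalen-2-yl in place of naphthalen-1-yl on an aromatic carbon): naphthalen-2-yl stands in place of naphthalen-1-yl on an aromatic carbon. Among the compounds with values here, no measured pair shows such a swap, so with compound 2 at 215 nM as the closest guide, no step beyond the scatter is expected in this assay and no direction is favoured. The estimated step is small (a 1.1-fold higher number from compound 2 to compound 4 (0.05 log units; within the scatter)). For compound 4 the expected value is 240 nM with an estimated range from 90 nM to 640 nM across repeated measurements.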

Compound 4, half-maximal inhibitory concentration: 18.8 nM
Compound 4: the middle estimate sits 13-fold (1.11 log units) above what was measured, outside the stated range (below it).
By their numbers in this assay, from the lowest: compound 4; then compounds 1 and 2 (each within the scatter of the next); then compound 3.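

In this assay, moving the attachment from naphthalen-1-yl to naphthalen-2-yl gives an 11-fold lower number from compound 2 to compound 4 (1.06 log units; beyond the scatter) as a large step, although the same atoms are present on both sides. Within the data shown here, at this position, para to the amide-bearing substituent and ortho to the sec-butoxy group, the point of attachment of the naphthalene therefore matters greatly, which the earlier compounds could not show, as none of them differed in one place. Nothing available explains this step. From the compounds shown here alone, whether the step would persist with a smaller group such as phenyl, or with an aminomethyl group or a carboxylic acid on the naphthalen-2-yl, stays open.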